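The source may report more compounds than this note shows. Statements on the series, on what has been measured and on what is new or still open speak of the compounds shown alone.

Measured so far:
- Compound 1, `CNc1nncc2cncn12`, in a functional assay for inhibition, with Homo sapiens as the target (on this read-out lower numbers stand for stronger inhibition and higher numbers for weaker inhibition), gives > 48000 nM.
- Compound 2, `CNc1nncc2c(C)ncn12`, gives > 48000 nM.
- Compound 3, `CCOC(=O)CSc1nncc2c(C)nc(C)n12`, gives > 48000 nM.

Each of these three values is a limit of the assay, not a number: the compound did not inhibit strongly enough to be pinned down. This is the evidence (the limit of > 48000 nM in this assay, at which 3 of the 3 values shown sit), and it is the whole of what the measurements show. The step from compound 2 to compound 1, hydrogen in place of methyl on an aromatic carbon, is therefore a step that the two limits leave unreadable from compound 2 to compound 1; the change is hydrogen in place of methyl on an aromatic carbon. The difference between the cores of compound 3 and compound 2 is not broken down here.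

Compound 4, `CCOC(=O)CSc1nncc2c(C)ncn12`, is not yet measured. It comes from compound 3 by hydrogen in place of methyl on an aromatic carbon. This is the same kind of change as from compound 2 to compound 1, but not the same: there the methyl sat next to the ring nitrogen, two ring bonds from the ring nitrogen, whereas here it sits between two ring nitrogen atoms, two ring bonds from the ring atom that bears a methyl group. The earlier step cannot be read because the limit of > 48000 nM in this assay, at which 3 of the 3 values shown sit, places both values at the limit, so it gives no size to carry over.

The expectation for compound 4 therefore rests on compound 3 alone, whose value > 48000 nM is a limit, and the step from compound 3 to compound 4 is estimated at a step that the limit leaves unreadable from compound 3 to compound 4. Compound 4 is expected to give about 60000 nM, plausibly between 15000 nM and 250000 nM, most likely reported again as a limit.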

Compound 4, half-maximal inhibitory concentration: > 48000 nM
Compound 4 was reported as a limit (the forecaster's own chance of this, stated with the estimate: 85%); the middle value is on the limit's open side.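

Compound 3 and compound 4 both sit at a limit of the assay rather than at a number, so the step between them, hydrogen in place of methyl, cannot be read because of this: the limit of > 48000 nM in this assay, at which 4 of the 4 values shown sit.

On these data alone, how strongly any of the four compounds inhibits in this assay stays open, and so does whether hydrogen or methyl at either place makes any difference there.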